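Dichloro urea analogue expected to stay above cytotoxicity limit

The source may report more compounds than this note shows. Statements on the series, on what has been measured and on what is new or still open speak of the compounds shown alone.

Three ureas were examined in an ADME assay on HEK293 cells (Homo sapiens) for cytotoxicity, with a stated time of 72 h; a higher number here means that more compound is needed for the effect, a lower number that less compound is needed. Compound 1 `Cc1cc(NC(=O)Nc2ccc(C)c(Cl)c2)c2ccccc2n1` reached only the limit of the assay, > 25000 nM. Compound 2 `Cc1ccc(NC(=O)Nc2cc(C)nc3ccccc23)cc1` likewise gave only a limit, > 25000 nM. Compound 3 `Cc1cc(NC(=O)Nc2ccc(Cl)cc2)c2ccccc2n1` also stopped at a limit, > 25000 nM. Compound 1 differs from compound 2 by chloro in place of hydrogen on an aromatic carbon, yet the step that the two limits leave unreadable from compound 2 to compound 1 cannot be sized because of the limit of > 25000 nM in this assay, at which 3 of the 3 values shown sit. The cores of compound 3 and compound 2 differ by chloro in place of methyl on an aromatic carbon, and a step that the two limits leave unreadable from compound 2 to compound 3 is equally unreadable. Compound 4 `Cc1cc(NC(=O)Nc2ccc(Cl)cc2Cl)c2ccccc2n1` carries the same kind of change relative to compound 3, (chloro in place of hydrogen on an aromatic carbon), but here the chloro enters ortho to a large group and meta to a chloro group, not ortho to a methyl group and meta to a large group. The expectation for compound 4 rests on compound 3 showing only the limit > 25000 nM. Compound 4 is expected to give 30000 nM, an expected step that the limit leaves unreadable from compound 3 to compound 4, most probably again reported only as a limit.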

Compound 4, half-maximal effective concentration: 10000 nM
The estimate for compound 4 lay 3.0-fold (0.48 log units) above the measured number; the measured number lies below the stated range.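

In this assay the chloro that enters ortho to a large group and meta to a chloro group gives an at least 2.5-fold lower number from compound 3 to compound 4 (0.39 log units; beyond the scatter), so in this one pair the change lowers the number. Among these compounds, the same change from compound 2 to compound 1 cannot be read, and neither can the other step among the earlier compounds, because their values are only limits: the limit of > 25000 nM in this assay, at which 3 of the 4 values shown sit. This single readable pair therefore does not show that the change carries from one core to another, nor whether its size depends on the core or on the place it enters.

The compounds shown leave open whether a group other than chloro at that place, such as an amine or a carboxylic acid, would also lower the number.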